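This account rests on a few compounds, and the source may have more. Where it says the series, first, only, none or still open, it means among the compounds named here.

Measured so far in an ADME assay on HaCaT cells (Homo sapiens) for cytotoxicity, read by MTT assay, with a stated time of 72 h; on this read-out higher numbers stand for weaker inhibition and lower numbers for stronger inhibition:
compound 1 `Cc1cc(S(=O)(=O)/N=C(\N)n2nccc2-c2ccccc2)c(SCc2ccccc2C)cc1Cl` gives 18000 nM;
compound 2 `Cc1cc(S(=O)(=O)/N=C(\N)n2nccc2-c2ccccc2)c(SCc2cccc(C(F)(F)F)c2)cc1Cl` gives 18000 nM;
compound 3 `Cc1cc(S(=O)(=O)/N=C(\N)n2nccc2-c2ccccc2)c(SCc2ccccc2Cl)cc1Cl` gives 20000 nM.

Compound 3 has the largest of the three numbers, yet a 1.1-fold higher number from compound 1 to compound 3 (0.05 log units; within the scatter) and a 1.1-fold higher number from compound 2 to compound 3 (0.05 log units; within the scatter), so the three sit together. The step to compound 4 `Cc1cc(S(=O)(=O)/N=C(\N)n2nccc2-c2ccccc2)c(SCc2ccccc2C(F)(F)F)cc1Cl` is trifluoromethyl in place of chloro on an aromatic carbon. Among the compounds with values here, two measured steps touch the same benzyl part of the shared core: no change at the digits printed from compound 1 to compound 2 (within the scatter), and a 1.1-fold higher number from compound 2 to compound 3 (0.05 log units; within the scatter). Neither moved the number beyond the scatter, so for compound 4 in this assay a step of a 1.1-fold lower number from compound 3 to compound 4 (0.02 log units; within the scatter) is expected, which is no change beyond the scatter. Compound 4 is therefore estimated at 19000 nM, within a range of 9000 nM to 40000 nM.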

Compound 4, half-maximal inhibitory concentration: 20000 nM
Compound 4: the middle estimate sits 1.1-fold (0.02 log units) below what was measured; measured number inside the range.
By their numbers in this assay, from the lowest: compounds 1, 2, 3 and 4 (each within the scatter of the next).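

In this assay trifluoromethyl in place of chloro on this aromatic carbon, ortho to a large group, gives no change at the digits printed from compound 3 to compound 4 (within the scatter) and adds a larger group without a shift beyond the scatter. Trifluoromethyl in place of methyl gives a 1.1-fold higher number from compound 1 to compound 4 (0.05 log units; within the scatter) at the same place, and 2-(trifluoromethyl)phenyl in place of 3-(trifluoromethyl)phenyl gives a 1.1-fold higher number from compound 2 to compound 4 (0.05 log units; within the scatter) as a comparison of one group at two places that the earlier compounds did not offer. No measurement here explains this flat result. The compounds shown leave open whether an amine or a carboxylic acid on this ring would move the number beyond the scatter.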